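A few compounds are considered here, and "the series" means these few. Any claim that something is new, unique, unknown or untested is made for them only; others in the source may bear on it.

Working notes on the series. Of the compounds shown here, three have been measured in an ADME assay on MT4 cells (Homo sapiens) for cytotoxicity, read by MTT assay; a lower number here means that less compound is tolerated, a higher number that more compound is tolerated: compound 1 `COc1cccc2c1c(C(=O)/C=C(\O)C(=O)O)cn2Cc1ccc(F)c(F)c1`, compound 2 `CCOC(=O)/C(O)=C/C(=O)c1cn(Cc2ccc(F)c(F)c2)c2cccc(OC)c12` and compound 3 `COc1cccc2c1c(C(=O)/C=C(\O)C(=O)O)cn2Cc1ccccc1F`, all on the same core. In this assay compound 1 gives 71000 nM. Compound 2 gives 125000 nM, the highest of the three numbers, though the separation is slight: a 1.8-fold higher number from compound 1 to compound 2 (0.25 log units; within the scatter). Compound 3 gives 70500 nM, and the swap of the aryl group on the saturated chain carbon bound to the aromatic nitrogen made no difference: a 1.0-fold lower number from compound 1 to compound 3 (0.00 log units; within the scatter).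

Compound 4 `CCOC(=O)/C(O)=C/C(=O)c1cn(Cc2cccc(F)c2)c2cccc(OC)c12` has not yet been measured. It differs from compound 2 in one place: hydrogen in place of fluoro on an aromatic carbon, which cut one bond further out reads 3,4-difluorophenyl to 3-fluorophenyl. Going by the values given here, two measured steps bear on this. Among the compounds with values here, the only change so far at the aryl group, from compound 1 to compound 3, stayed within the scatter, and the ethyl-for-hydrogen step from compound 1 to compound 2 also stayed within the scatter. Nothing measured suggests that removing one fluoro should move the this assay number beyond the scatter in either direction. Compound 4 is therefore expected to give about 120000 nM, within 60000 nM to 240000 nM, an expected step of a 1.0-fold lower number from compound 2 to compound 4 (0.02 log units; within the scatter).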

Compound 4, half-maximal cytotoxic concentration: 63200 nM
Compound 4: the middle estimate sits 1.9-fold (0.28 log units) above what was measured; measured number inside the range.
By their numbers in this assay, from the lowest: compounds 4, 3, 1 and 2 (each within the scatter of the next).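

Hydrogen in place of fluoro on this aromatic carbon, ortho to a fluoro group and para to a large group, is the first aryl change read among the compounds that carry the ethyl group, and in this assay it stays within the scatter (a 2.0-fold lower number from compound 2 to compound 4 (0.30 log units; within the scatter)). Going by these compounds alone, the only earlier aryl step, (a 1.0-fold lower number from compound 1 to compound 3 (0.00 log units; within the scatter)), was read with hydrogen in place of that ethyl and was a different swap, so the two steps together show that neither aryl change has carried the number beyond the scatter, with or without the ethyl group. No measurement on hand accounts for the size of the step from 3,4-difluorophenyl to 3-fluorophenyl.

The compounds shown leave open whether chloro, methyl or trifluoromethyl on this aromatic carbon, or a benzyl group with no fluoro at all, would stay within the scatter of compound 2. They also leave open how the 3-fluorobenzyl group reads with the free carboxylic acid of compound 1 in place of the ethyl ester.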